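This account rests on a few compounds, and the source may have more. Where it says the series, first, only, none or still open, it means among the compounds named here.

Three compounds share one core and differ only in the aryl group on the carbon with a double bond to nitrogen. Compound 1 `Cc1c(C(=O)N/N=C\c2cc(F)ccc2O)oc2cccc(O)c12` gives 5230 nM in a functional assay on MGC-803 cells (Homo sapiens) for inhibition, read by MTT assay (on this read-out higher numbers stand for weaker inhibition and lower numbers for stronger inhibition), compound 2 `Cc1c(C(=O)N/N=C\c2cccc(O)c2O)oc2cccc(O)c12` gives 5030 nM, and compound 3 `Cc1c(C(=O)N/N=C\c2c(O)cccc2F)oc2cccc(O)c12` gives 10800 nM. Compound 3 thus carries the highest number of the three: the step of a 2.1-fold higher number from compound 1 to compound 3 (0.31 log units; beyond the scatter) and the step of a 2.1-fold higher number from compound 2 to compound 3 (0.33 log units; beyond the scatter) both lie beyond the scatter, while the step of a 1.0-fold lower number from compound 1 to compound 2 (0.02 log units; within the scatter) does not.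

Compound 4 `Cc1c(C(=O)N/N=C\c2cccc(Br)c2O)oc2cccc(O)c12` is not yet measured. It differs from compound 3 as follows: 3-bromo-2-hydroxyphenyl in place of 2-fluoro-6-hydroxyphenyl on a carbon with a double bond to nitrogen. Going by the values given here, the two steps that bear on this change are those leading into compound 3, since both remove a group that, like the one entering compound 4, is a 2-hydroxyphenyl bearing one further substituent, and both were modest rises. Reversing that direction, the number for compound 4 is expected to fall back to the level of compounds 1 and 2, giving an expected step of a 2.0-fold lower number from compound 3 to compound 4 (0.29 log units; within the scatter). Compound 4 is therefore estimated at 5500 nM, within a range from 2500 nM to 12000 nM.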

Compound 4, half-maximal inhibitory concentration: 14200 nM
Estimate against measurement, compound 4: 2.6-fold (0.41 log units) below; the measured number lies above the stated range.
By their numbers in this assay, from the lowest: compounds 2 and 1 (each within the scatter of the next); then compounds 3 and 4 (each within the scatter of the next).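

In this assay, a 2-hydroxyphenyl with one further substituent at this position does not by itself keep a compound at the level of compounds 1 and 2: the exchange of 2-fluoro-6-hydroxyphenyl for 3-bromo-2-hydroxyphenyl gives a 1.3-fold higher number from compound 3 to compound 4 (0.12 log units; within the scatter) and so leaves the number where it was. Bromo in place of hydroxy on an aromatic carbon gives a 2.8-fold higher number from compound 2 to compound 4 (0.45 log units; beyond the scatter) and the change from 5-fluoro-2-hydroxyphenyl gives a 2.7-fold higher number from compound 1 to compound 4 (0.43 log units; beyond the scatter), so these four aryl groups fall into two levels, with compounds 1 and 2 on one and compounds 3 and 4 on the other. Nothing measured here explains this split.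

On these data alone, it remains open whether chloro or methoxy in place of the bromo, or an amine on the same ring, would join the lower or the higher level. The four compounds also leave open whether the two levels would persist with the hydroxy group of the aryl ring removed altogether.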